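The compounds below may be only part of what the source reports. "The series", "measured", "known", "first", "only" and "open" are said of these compounds alone.

Going by the values given here, in a functional assay on KBVIN cells (Homo sapiens) for cytotoxicity, read by sulforhodamine B assay, with a stated time of 3 days (a lower number here means that less compound is needed, a higher number that more compound is needed for the effect), compound 1 `COC(=O)c1c(C)coc1-c1ccc2c(c1OC)CCCC2(C)C` gives 52.1 uM and compound 2 `COc1c(-c2occ(C)c2COC(C)=O)ccc2c1CCCC2(C)C` gives 24.9 uM, the lower of the two numbers so far. Compound 3 `COCc1c(C)coc1-c1ccc2c(c1OC)CCCC2(C)C` is not yet measured. It has methyl in place of acetyl on an oxygen on a saturated carbon, acetoxymethyl to methoxymethyl: methyl in place of acetyl on an oxygen on a saturated carbon. Among the compounds with values here, the only measured step, a 2.1-fold lower number from compound 1 to compound 2 (0.32 log units; beyond the scatter), is modest and is a different change, so it bears only indirectly. A small move towards a higher number in this assay is expected, possibly none beyond the scatter. The expected step is a 1.3-fold higher number from compound 2 to compound 3 (0.11 log units; within the scatter). For compound 3 the estimate is 32 uM, with an expected range of 15 uM to 65 uM.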

Compound 3, concentration for half-maximal effect: 20.1 uM
Compound 3: the middle estimate sits 1.6-fold (0.20 log units) above what was measured, and the stated range covers the measured number.
By their numbers in this assay, from the lowest: compounds 3 and 2 (each within the scatter of the next); then compound 1.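

In this assay, methyl in place of acetyl on the oxygen leaves the number within the scatter (a 1.2-fold lower number from compound 2 to compound 3 (0.09 log units; within the scatter)), so at this position the acetyl group is not required to hold this level. Measured against the methoxycarbonyl group, the methoxymethyl group gives a modest step (a 2.6-fold lower number from compound 1 to compound 3 (0.41 log units; beyond the scatter)) in the same direction as the acetoxymethyl replacement. No evidence bears on the reason for either step.

Still open, going by these compounds, is whether hydroxymethyl, an aminomethyl group or a carboxylic acid at this place would shift the number further.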